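The source may hold more compounds than are shown below. What is called first, only, known or untested is meant among the compounds shown, and "the series" means these compounds.

Measured in a functional assay on B16 cells (Mus musculus) for cytotoxicity, read by MTT assay, with a stated time of 48 h; a higher number here means a weaker inhibitor, a lower number a stronger inhibitor:

- compound 1 `O=C(NCc1cn(Cc2ccccc2)nn1)c1cn(Cc2ccccc2)nn1`: 300 nM
- compound 2 `O=C(Cn1cc(C(=O)NCc2cn(Cc3ccccc3)nn2)nn1)OCc1ccccc1`: 22400 nM

Of these two numbers, compound 2 has the higher at 22400 nM, so it is the weaker inhibitor of the pair. The gap is a 75-fold higher number from compound 1 to compound 2 (1.87 log units; beyond the scatter), well beyond the scatter.

The next compound, compound 3 `CC(=O)OCCn1cc(CNC(=O)c2cn(CC(=O)OCc3ccccc3)nn2)nn1`, is made from compound 2 by one change: acetoxymethyl in place of phenyl on a saturated chain carbon bound to an aromatic nitrogen. Put another way, benzyl gives way to 2-acetoxyethyl. Among the measured compounds shown here, only one measured step bears on this. It also removed a phenyl on a saturated chain carbon bound to an aromatic nitrogen, with benzyloxycarbonyl entering there, and the result was a 75-fold higher number from compound 1 to compound 2 (1.87 log units; beyond the scatter). That single large step points towards a higher number in this assay when this phenyl is lost too. However, the entering group differs, and one step gives no firm measure of size, so a smaller rise is expected. The expected change is a 2.7-fold higher number from compound 2 to compound 3 (0.43 log units; beyond the scatter). For compound 3 the estimated value is 60000 nM, with an expected range of 15000 nM to 220000 nM.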

Compound 3, half-maximal inhibitory concentration: > 100000 nM
Compound 3 was reported as a limit (the forecaster's own chance of this, stated with the estimate: 25%); at least 1.6-fold (0.22 log units) between middle value and limit.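

Replacing benzyl with 2-acetoxyethyl gave an at least 4.4-fold higher number from compound 2 to compound 3 (0.64 log units; beyond the scatter) in this assay. This was the second exchange of a phenyl on a saturated chain carbon bound to an aromatic nitrogen to raise the number beyond the scatter, following a 75-fold higher number from compound 1 to compound 2 (1.87 log units; beyond the scatter), so neither benzyloxycarbonyl nor acetoxymethyl matched phenyl at this kind of place in the two steps shown. Compound 3 is reported only as a limit, > 100000 nM, so its step has a lower bound but no fixed size: the limit of > 100000 nM in this assay, at which 1 of the 3 values shown sits.

The compounds shown do not separate the loss of the aromatic ring from the arrival of the acetoxymethyl group, which has no ring and carries 2 hydrogen-bond acceptors. From the compounds shown here alone, a 2-phenylethyl group, a plain ethyl, a 2-hydroxyethyl or a pyridylmethyl at the same place could tell these apart, and whether the ester in 2-acetoxyethyl matters at all, or the ring alone, remains open.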